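A few compounds are considered here, and "the series" means these few. Any claim that something is new, unique, unknown or untested is made for them only; others in the source may bear on it.

Measured so far in an ADME assay on CCRF-CEM cells (Homo sapiens) for cytotoxicity, with a stated time of 72 h; on this read-out lower numbers stand for stronger inhibition and higher numbers for weaker inhibition:
- compound 1 `Clc1ccc(Cc2nn3c(Br)c(-c4ccc(Cl)cc4)nc3s2)cc1` — > 250000 nM, a limit of the assay rather than a number
- compound 2 `Clc1ccc(Cc2nn3c(Br)c(-c4ccc(Br)cc4)nc3s2)cc1` — 238000 nM

Compound 1 stands only at a limit in this assay, as shown by the limit of > 250000 nM in this assay, at which 1 of the 2 values shown sits. Among the measured compounds shown here, the single measured step, an at least 1.0-fold lower number from compound 1 to compound 2 (0.02 log units; that floor lies within the scatter), is within the scatter, so the two analogues show the same picture of weak cytotoxicity.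

Compound 3 `O=Cc1c(-c2ccc(Cl)cc2)nc2sc(Cc3ccc(Cl)cc3)nn12` differs from compound 1 by formyl in place of bromo on an aromatic carbon. For the measured compounds named here, no measured step covers a formyl group at this place; the only measured change, bromo in place of chloro on the 4-halophenyl ring, an at least 1.0-fold lower number from compound 1 to compound 2 (0.02 log units; that floor lies within the scatter), bears on a different position and gives no movement beyond the scatter. On that basis compound 3 is expected to stay in the same weak range as compound 1, with the step of a number no higher from compound 1 to compound 3 (the limit leaves the size open) expected to be none beyond the scatter. The estimate for compound 3 in this assay is 250000 nM, expected between 90000 nM and 700000 nM.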

Compound 3, half-maximal inhibitory concentration: 5800 nM
Compound 3: middle estimate off by 43-fold (1.63 log units), on the high side, and the stated range ends above it.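

The aromatic carbon next to the ring nitrogen responds strongly in this assay: formyl in place of bromo gives an at least 43-fold lower number from compound 1 to compound 3 (1.63 log units; beyond the scatter). The halogen exchange on the other aromatic carbon gave an at least 1.0-fold lower number from compound 1 to compound 2 (0.02 log units; that floor lies within the scatter), so this is the first change shown to move the read-out beyond the scatter, and it shows that the weak picture of the first two analogues does not hold for every group at this place. The full size of the step stays open because the starting compound stands at a limit: the limit of > 250000 nM in this assay, at which 1 of the 3 values shown sits.

Going by these compounds, whether the drop is tied to the formyl group itself or would also appear with a carboxylic acid, a hydroxymethyl group or an amine at this place remains open. Also open, on these data alone, is whether formyl gives a similar step on the core of compound 2.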